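Ethyl ester variant of the alkynyl ether series

The source may report more compounds than this note shows. Statements on the series, on what has been measured and on what is new or still open speak of the compounds shown alone.

Compound 2 `COC(=O)C#CC(O/C=C/C(=O)OC)C(C)C` gives 450 nM in a functional assay on HBL-100 cells (Homo sapiens) for antiproliferative activity, read by sulforhodamine B assay, with a stated time of 48 h; a higher number here means a weaker inhibitor of growth, a lower number a stronger inhibitor of growth. Among the three measured members it stands second highest; compound 1 `COC(=O)C#CC(CC(C)C)O/C=C/C(=O)OC` gives 330 nM, and compound 3 `COC(=O)C#CC(O/C=C/C(=O)OC)C(C)(C)C` gives 1800 nM. The step of a 1.4-fold higher number from compound 1 to compound 2 (0.13 log units; within the scatter) is within the scatter, whereas a 4.0-fold higher number from compound 2 to compound 3 (0.60 log units; beyond the scatter) and a 5.5-fold higher number from compound 1 to compound 3 (0.74 log units; beyond the scatter) are modest steps beyond it, both at the branched carbon bound to the oxygen on the unsaturated carbon.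

Among the compounds with values here, compound 4 `CCOC(=O)C#CC(O/C=C/C(=O)OC)C(C)C` differs from compound 2 by methyl in place of hydrogen on a saturated chain carbon bound to an oxygen next to a carbonyl group, that is at the ester on the triple-bonded side, a position none of the measured steps touches. Within the data shown here, the only step that adds a methyl, a 4.0-fold higher number from compound 2 to compound 3 (0.60 log units; beyond the scatter), sits on a saturated chain carbon bound to three saturated chain carbons and so offers no direct guide. With no comparable change measured, the expectation for compound 4 is a step within the scatter, a 1.1-fold higher number from compound 2 to compound 4 (0.05 log units; within the scatter), in no set direction. Compound 4 is therefore expected at 500 nM in this assay, estimated between 220 nM and 1200 nM.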

Compound 4, concentration for 50% growth inhibition: 880 nM
Compound 4: the middle estimate sits 1.8-fold (0.25 log units) below what was measured; the range from low to high includes it.
By their numbers in this assay, from the lowest: compounds 1, 2 and 4 (each within the scatter of the next, the first and the last beyond it); then compound 3.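

Methoxycarbonyl to ethoxycarbonyl is the first change in the series away from the branched carbon, and in this assay it gives a 2.0-fold higher number from compound 2 to compound 4 (0.29 log units; within the scatter). A single added methyl on a saturated chain carbon bound to an oxygen next to a carbonyl group therefore keeps growth inhibition in the range of compound 2, and this one pair cannot separate the step from repeat variation. No supporting data bear on the size of this step.

Still open, going by these compounds, is whether a longer chain such as propoxycarbonyl or butoxycarbonyl, or a free carboxylic acid or an amide in place of the ester, would hold the read-out in that range. Also open, on these data alone, is whether ethoxycarbonyl would behave the same way on the isobutyl member compound 1 and the tert-butyl member compound 3.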